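Three Ethoxyphenyl Triazole Analogues and a Positional Isomer

The source may hold more compounds than are shown below. What is called first, only, known or untested is meant among the compounds shown, and "the series" means these compounds.

Measured so far, each in an ADME assay on HUVEC cells (Homo sapiens) for antiproliferative activity, read by MTT assay, with a stated time of 48 h; a lower number here means a stronger inhibitor, a higher number a weaker inhibitor:
Compound 1 `CCOc1ccccc1-n1nncc1CN1C(=O)C2(C(C#N)=C(N)Oc3c2c2nc4ccccc4nc2c2ccccc32)c2ccccc21`: compound 1 gives > 50000 nM, which is a limit of the assay and not a number.
Compound 2 `CCOc1ccc(-n2nncc2CN2C(=O)C3(C(C#N)=C(N)Oc4c3c3nc5ccccc5nc3c3ccccc43)c3ccccc32)cc1`: compound 2 gives > 50000 nM, again a limit rather than a number.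
Compound 3 `CCOc1ccc(-n2nncc2CN2C(=O)C3(C(C#N)=C(N)Oc4c(N)cc5nc6ccccc6nc5c43)c3ccccc32)cc1`: compound 3 gives > 50000 nM, also a limit.

Compound 1 and compound 2 share one core and differ in a single place: 2-ethoxyphenyl in place of 4-ethoxyphenyl on an aromatic nitrogen. The step that the two limits leave unreadable from compound 2 to compound 1 cannot be read, because both values sit at the limit of > 50000 nM in this assay, at which 3 of the 3 values shown sit. Compound 3 carries a different core; the difference between the two cores and that of compound 2 is not broken down here.

Compound 4 `CCOc1ccccc1-n1nncc1CN1C(=O)C2(C(C#N)=C(N)Oc3c(N)cc4nc5ccccc5nc4c32)c2ccccc21` has not yet been measured in this assay. It is related to compound 3 by the same kind of change that relates compound 1 to compound 2: 2-ethoxyphenyl in place of 4-ethoxyphenyl on an aromatic nitrogen. The place descriptions of the two changes agree word for word, so this is the same change on a different core.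

What can be expected rests only on the three measured values. For the measured compounds named here, all three sit at the limit of > 50000 nM in this assay, at which 3 of the 3 values shown sit, and the one measured instance of this change, a step that the two limits leave unreadable from compound 2 to compound 1, gives no readable size. The step from compound 3 to compound 4 is therefore estimated as a step that the limit leaves unreadable from compound 3 to compound 4, essentially no movement. Compound 4 is estimated at 70000 nM in this assay, within 25000 nM to 250000 nM, with the most likely outcome being another limit rather than a number.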

Compound 4, half-maximal inhibitory concentration: > 50000 nM
Compound 4: a limit, no number; the forecaster's own chance of this, stated with the estimate: 85%; the middle value does not contradict the limit.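

In this assay compound 4 gives > 50000 nM, which is a limit of the assay and not a number. No size can be read for the change from compound 3 to compound 4, because both values sit at the same limit: the limit of > 50000 nM in this assay, at which 4 of the 4 values shown sit.

The compounds shown leave open whether 2-ethoxyphenyl in place of 4-ethoxyphenyl changes activity at all on either core.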